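Swapping a Methylsulfonyl for a Cyano Group

The source may report more compounds than this note shows. Statements on the series, on what has been measured and on what is new or still open speak of the compounds shown alone.

Compound 1 `CC(C)(C)OC(=O)N1CCC(O[C@H]2CC[C@H](Oc3ccc(S(C)(=O)=O)cc3)CC2)CC1` was tested in a functional assay on isolated protein for agonist activity at Glucose-dependent insulinotropic receptor (Homo sapiens), read by HTRF and cAMP accumulation (on this read-out lower numbers stand for an effect already at smaller amounts and higher numbers for an effect only at larger amounts of compound), where it gives 16.1 nM. Within the data shown here, only one other compound of this set has been measured: compound 2 `CC(C)(C)OC(=O)N1CCC(O[C@H]2CC[C@H](Oc3ccc(S(C)(=O)=O)cc3F)CC2)CC1`, which gives 8.5 nM in this assay. The step of a 1.9-fold lower number from compound 1 to compound 2 (0.28 log units; within the scatter) lies within the scatter of repeated measurements, so the two compounds cannot be told apart on these numbers; compound 1 simply holds the larger of the two figures shown.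

Compound 3 `CC(C)(C)OC(=O)N1CCC(O[C@H]2CC[C@H](Oc3ccc(C#N)cc3)CC2)CC1` differs from compound 1 in one place: cyano in place of methylsulfonyl on an aromatic carbon. Among the measured compounds shown here, none of the measured steps bears on this change, as the single step available exchanges only a hydrogen for a fluoro and leaves the methylsulfonyl untouched. For the measured compounds named here, with no comparable step to lean on, the expectation for compound 3 in this assay is a step of a 2.5-fold higher number from compound 1 to compound 3 (0.40 log units; beyond the scatter), an estimated value of 40 nM with a range from 8 nM to 200 nM.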

Compound 3, half-maximal effective concentration: 8.6 nM
The estimate for compound 3 lay 4.7-fold (0.67 log units) above the measured number; the range from low to high includes it.
By their numbers in this assay, from the lowest: compounds 2, 3 and 1 (each within the scatter of the next).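

In this assay the step of a 1.9-fold lower number from compound 1 to compound 3 (0.27 log units; within the scatter) shows that on this aromatic carbon, para to a large group, methylsulfonyl can be exchanged for cyano without a change that stands out from the scatter. The exchange puts a group of 2 heavy atoms in place of one of 4 and removes the sulfur, so across these two compounds the read-out does not depend on keeping a methylsulfonyl at this place. Nothing available explains why the two groups read alike.

As far as these compounds go, whether an amine, a carboxylic acid or a longer chain at this place would also stay within the scatter of compound 1 remains open. Also open, from the compounds shown here alone, is what the fluoro of compound 2 would do in a compound carrying cyano instead of methylsulfonyl.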